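Working notes: hydroxy to methoxy across two related cores

This account rests on a few compounds, and the source may have more. Where it says the series, first, only, none or still open, it means among the compounds named here.

Compound 1 `C=C(C)C[N+](C)(C)c1cccc(O)c1` is measured in a functional assay with Cavia porcellus as the target; on this read-out higher numbers stand for weaker inhibition and lower numbers for stronger inhibition. In this assay compound 1 gives > 3000 nM, which is a limit of the assay rather than a number. Compound 2 `C=C(C)C[N+](C)(C)c1cccc(OC)c1` carries methyl in place of hydrogen on an oxygen on an aromatic ring. In this assay compound 2 gives > 3000 nM, again a limit. The step that the two limits leave unreadable from compound 1 to compound 2 therefore cannot be read; the two limits hide its size. Compound 3 `C[N+](C)(Cc1ccccc1)c1cccc(O)c1` rests on a different core, and the difference between the two cores is not broken down here. In this assay compound 3 gives > 3000 nM, a limit as well. Compound 4 `COc1cccc([N+](C)(C)Cc2ccccc2)c1` carries methyl in place of hydrogen on an oxygen on an aromatic ring on compound 3, the same change made from compound 1 to compound 2, and the place reads the same word for word in both pairs: on an oxygen on an aromatic ring whose other neighbours are aromatic carbon. All three measured values sit at the limit of > 3000 nM in this assay, at which 3 of the 3 values shown sit. For the step in this assay, the expected size is a step that the limit leaves unreadable from compound 3 to compound 4, near no change, because the limit of > 3000 nM in this assay, at which 3 of the 3 values shown sit, is where compound 1, compound 2 and compound 3 all sit and the earlier step is not readable from them. Compound 4 is expected to give 6000 nM, most likely again only a limit.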

Compound 4, half-maximal inhibitory concentration: > 3000 nM
Compound 4: no number, only a limit; the forecaster's own chance of this, stated with the estimate: 85%; the middle value is on the limit's open side.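

In this assay compound 4 gives > 3000 nM, a limit of the assay and not a number. No new step can be read, neither from compound 3 to compound 4 nor from compound 2 to compound 4. The compounds shown leave open whether hydroxy to methoxy changes inhibition on either core, and how far compounds 1 to 4 lie beyond the limit.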